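The source may report more compounds than this note shows. Statements on the series, on what has been measured and on what is new or still open speak of the compounds shown alone.

Measured compounds in a functional assay on the whole organism (artery, strain albino) with Rattus norvegicus as the target, with a stated time of 600 min, at a dose of 10 mg/kg by the oral route; a lower number here means less inhibition, a higher number more inhibition at the dose given (going by the name of the read-out):
- compound 1, `CC1=C(C(=O)Nc2ccc(Br)cc2)C(c2ccc(Cl)cc2Cl)N=C(SCc2ccccc2Cl)N1`, where compound 1 gives 24.6%
- compound 2, `CC1=C(C(=O)Nc2ccc(Br)cc2)C(c2ccc(Cl)cc2Cl)N=C(SCc2ccc(Cl)cc2)N1`, where compound 2 gives 30.3%
- compound 3, `COc1ccc(C2N=C(SCc3ccccc3Cl)NC(C)=C2C(=O)Nc2ccc(Br)cc2)cc1`, where compound 3 gives 13.3%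

Compound 3 stands lowest of the three: its gap to compound 1 is beyond the scatter, and its gap to compound 2 is larger still. The step from compound 1 to compound 3 exchanged the group on the saturated ring carbon and read a number 11.3 percentage points lower from compound 1 to compound 3 (beyond the scatter).

Compound 4, `COc1ccc(C2N=C(SCc3ccc(Cl)cc3)NC(C)=C2C(=O)Nc2ccc(Br)cc2)cc1`, has not yet been measured. It differs from compound 3 in one place:

4-chlorophenyl in place of 2-chlorophenyl on a saturated chain carbon bound to a sulfur

The same exchange has been seen once before, in the step from compound 1 to compound 2, which gave a number 5.7 percentage points higher from compound 1 to compound 2 (within the scatter). Among the measured compounds shown here, only that one step bears on the present change, and it stayed within the scatter. Carried over to compound 3, it suggests at most a small rise, and no step beyond the scatter is expected. The expected step is a number 4.7 percentage points higher from compound 3 to compound 4 (within the scatter). Compound 4 is therefore estimated at 18%, with a range from 6% to 32%.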

Compound 4, a percentage reported as inhibition, in the whole organism at one dose (the size of the read-out at that dose, not a potency): 30.3%
Estimate against measurement, compound 4: 12.3 percentage points below, within the range that was stated.
By their numbers in this assay, from the lowest: compound 3; then compounds 1, 2 and 4 (each within the scatter of the next).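

On the core of compound 3, 4-chlorophenyl in place of 2-chlorophenyl on a saturated chain carbon bound to a sulfur gave a number 17 percentage points higher from compound 3 to compound 4 (beyond the scatter), so this change now appears as a step beyond the scatter in this assay, although the two cores do not truly part on it: the same change on two cores in this assay, a number 5.7 percentage points higher (within the scatter) from compound 1 to compound 2 and a number 17 percentage points higher (beyond the scatter) from compound 3 to compound 4, 11.3 percentage points apart, within the scatter of two such steps. With 4-chlorobenzyl on the sulfur, 4-methoxyphenyl in place of 2,4-dichlorophenyl on a saturated ring carbon gave no change at the digits printed from compound 2 to compound 4 (within the scatter), so the drop seen with 2-chlorobenzyl did not recur. That contrast also stays unresolved: the same change on two cores in this assay, a number 11.3 percentage points lower (beyond the scatter) from compound 1 to compound 3 and no change at the digits printed (within the scatter) from compound 2 to compound 4, 11.3 percentage points apart, within the scatter of two such steps.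

From the compounds shown here alone, it remains open how an unsubstituted benzyl or a longer chain such as phenethyl on the sulfur would read against the 4-chlorobenzyl group. Equally open, going by these compounds, is how a 4-hydroxyphenyl on the saturated ring carbon would read on either sulfur side chain.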